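The compounds below may be only part of what the source reports. "The series", "measured", "known", "first", "only" and "open" are said of these compounds alone.

Working notes on the series: in a functional assay on L02 cells (Homo sapiens) for inhibition (on this read-out higher numbers stand for weaker inhibition and lower numbers for stronger inhibition), compound 1 `O=C(CC(CC(=O)NC1Cc2ccccc2C1)c1ccc(Cl)cc1)NCCN1CCCC1` gives 89400 nM and compound 2 `CCN(C(=O)CC(CC(=O)NCCN1CCCCC1)c1ccc(Cl)cc1)C1Cc2ccccc2C1` gives 84200 nM. For the measured compounds named here, these two values lie within the scatter of each other, so compound 2 stands level with compound 1 on the numbers so far. Compound 3 `CCN(C(=O)CC(CC(=O)NCCN1CCCC1)c1ccc(Cl)cc1)C1Cc2ccccc2C1`, not yet measured, differs from compound 2 as follows: pyrrolidin-1-yl in place of piperidin-1-yl on a saturated chain carbon, two bonds along the chain from an amide-type nitrogen. Going by the values given here, no measured pair covers this change, and no step beyond the scatter is expected in this assay. The expected step is a 1.0-fold higher number from compound 2 to compound 3 (0.00 log units; within the scatter). For compound 3 the estimated value is 85000 nM, with an expected range of 45000 nM to 160000 nM.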

Compound 3, half-maximal inhibitory concentration: 54200 nM
The estimate for compound 3 lay 1.6-fold (0.20 log units) above the measured number; the range from low to high includes it.
By their numbers in this assay, from the lowest: compounds 3, 2 and 1 (each within the scatter of the next).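

In this assay, pyrrolidin-1-yl in place of piperidin-1-yl on a saturated chain carbon, two bonds along the chain from an amide-type nitrogen, gives a 1.6-fold lower number from compound 2 to compound 3 (0.19 log units; within the scatter), so this change of ring does not separate the two compounds. Ethyl in place of hydrogen on an amide-type nitrogen gives a 1.6-fold lower number from compound 1 to compound 3 (0.22 log units; within the scatter), so that change does not separate its pair either. On these data alone, whether morpholin-4-yl or dimethylamino in place of pyrrolidin-1-yl would give a step beyond the scatter stays open. Nothing at hand bears on a reason for these results.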